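This account rests on a few compounds, and the source may have more. Where it says the series, first, only, none or still open, it means among the compounds named here.

Among the measured compounds shown here, compound 3 `COc1cc(-c2nnc(SCC(=O)c3ccc(Cl)cc3)n2N2C(=O)c3ccccc3C2=O)cc(OC)c1OC` gives the only number in the set: in a functional assay on A549 cells (Homo sapiens) for cytotoxicity, read by MTT assay, with a stated time of 48 h (on this read-out lower numbers stand for stronger inhibition and higher numbers for weaker inhibition), compound 3 reads 9030 nM. Compound 2 `COc1cc(-c2nnc(SCc3ccccc3Cl)n2N2C(=O)c3ccccc3C2=O)cc(OC)c1OC` reports only a limit, > 200000 nM. Compound 1 `CCc1nnc(SCC(=O)c2ccccc2)n1N1C(=O)c2ccccc2C1=O` likewise reports only a limit, > 200000 nM. For the measured compounds named here, the one measured step, an at least 22-fold lower number from compound 2 to compound 3 (1.34 log units; beyond the scatter), starts from a limit, so its size is itself a lower bound (the limit of > 200000 nM in this assay, at which 2 of the 3 values shown sit). Compound 4 `COc1cc(-c2nnc(SCC(=O)c3ccccc3)n2N2C(=O)c3ccccc3C2=O)cc(OC)c1OC` differs from compound 3 by hydrogen in place of chloro on an aromatic carbon. Going by the values given here, no measured step removes a chloro alone; the step into compound 3 changed both the carbonyl and the chloro position at once, and compound 1, which also carries benzoylmethyl but a different group on the shared core, sits at a limit. A modest loss is therefore expected, as a 2.0-fold higher number from compound 3 to compound 4 (0.30 log units; within the scatter). Compound 4 is estimated at 18000 nM, within 5000 nM to 70000 nM.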

Compound 4, half-maximal inhibitory concentration: > 200000 nM
Compound 4 was reported as a limit; the forecaster's own chance of this, stated with the estimate: 20%; middle value at least 11-fold (1.04 log units) away from the limit.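

Among the compounds shown here, removing the chloro para to a large group is the first change at this position read alone, and in this assay it gives an at least 22-fold higher number from compound 3 to compound 4 (1.34 log units; beyond the scatter). For the compounds shown here, with the rest of the structure unchanged, the chloro separates the one compound with a number, compound 3, from compound 4. The steps from compound 2 and from compound 1 to compound 4 cannot be read, both ends being limits, and the size of the chloro step is a lower bound: the limit of > 200000 nM in this assay, at which 3 of the 4 values shown sit.

Going by these compounds, whether fluoro, bromo, methoxy or an amine at this place would retain a number stays open. The compounds shown also leave open whether the chloro would matter on the core of compound 1.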